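A few compounds are considered here, and "the series" means these few. Any claim that something is new, unique, unknown or untested is made for them only; others in the source may bear on it.

Working notes on the series. Compound 1 `CC1(C)C=C(n2ccccc2=O)c2cc(OC(=O)Nc3ccccc3)ccc2O1` and compound 2 `CC1(C)C=C(n2ccccc2=O)c2cc(OC(=O)Nc3ccccc3C(F)(F)F)ccc2O1` share one core and differ only in the trifluoromethyl in place of hydrogen on an aromatic carbon. In a functional assay (trachea) with Rattus norvegicus as the target (a higher number here means a more potent compound, by a factor of ten per unit of this negative logarithm, a lower number a less potent compound), compound 1 gives 4.89, and compound 2 gives 5.19. The step of a number 0.30 log units higher from compound 1 to compound 2 (within the scatter) leaves the two within the usual scatter of one another, so compound 2 stands at the higher of two numbers without a separation that can be trusted.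

Compound 3 `CC1(C)C=C(n2ccccc2=O)c2cc(OC(=O)Nc3ccc(C(F)(F)F)cc3)ccc2O1` keeps the same atoms of compound 2 joined differently: 4-(trifluoromethyl)phenyl in place of 2-(trifluoromethyl)phenyl on an amide-type nitrogen. Among the compounds with values here, the one measured step, a number 0.30 log units higher from compound 1 to compound 2 (within the scatter), shows only that adding the trifluoromethyl at all changed little; no measured pair speaks to moving it within the ring. On that basis no step beyond the scatter is expected, and a number 0.09 log units lower from compound 2 to compound 3 (within the scatter) is the estimated change. Compound 3 is therefore expected at 5.1 in this assay, within 4.6 to 5.6.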

Compound 3, logarithm of the reciprocal of the active concentration, log(1/C): 4.54
For compound 3 the middle estimate is 0.56 log units above the measured one; measured number outside the range, below it.
By their numbers in this assay, from the lowest: compound 3; then compounds 1 and 2 (each within the scatter of the next).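

In this assay, where the trifluoromethyl sits now matters: 4-(trifluoromethyl)phenyl in place of 2-(trifluoromethyl)phenyl on the amide-type nitrogen gives a number 0.65 log units lower from compound 2 to compound 3 (beyond the scatter), a modest step beyond the scatter. Adding the trifluoromethyl is therefore not neutral in every case: a number 0.35 log units lower from compound 1 to compound 3 (beyond the scatter), also modest and beyond the scatter, whereas the step to compound 2 stayed within it. No measurement available here accounts for the difference between the two arrangements.

As far as these compounds go, it remains open whether a nitrile or a methoxy group at these two places on the phenyl would show the same order. With trifluoromethyl as the only substituent shown, the result cannot be extended to other groups on this ring.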